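The compounds below may be only part of what the source reports. "The series", "measured", "known", "first", "only" and "open" are said of these compounds alone.

Measured compounds in an assay on CHO cells for displacement of a labelled ligand from adenosine receptor A1 (Homo sapiens), read by scintillation counting, tested at 10 uM; on this read-out higher numbers stand for more inhibition at the one concentration tested (going by the name of the read-out) and lower numbers for less inhibition:
Compound 1 `CC(C)(C)Cc1csc(N)c1C(=O)c1ccc(Cl)cc1` gives 1%.
Compound 2 `CC(C)(C)Cc1c(-c2ccc(Cl)c(Cl)c2)sc(N)c1C(=O)c1ccc(Cl)cc1` gives 1%.
Compound 3 `CC(C)(C)Cc1c(-c2ccccc2)sc(N)c1C(=O)c1ccc(Cl)cc1` gives 1%.

On these numbers compound 3 stands level with compound 1 and compound 2: all three read within the scatter of one another, so no ordering among them can be drawn from this assay. The three steps that connect them all fall within the scatter: no change at the digits printed from compound 1 to compound 2 (within the scatter), no change at the digits printed from compound 1 to compound 3 (within the scatter) and no change at the digits printed from compound 2 to compound 3 (within the scatter). Each of those steps changes the group on the aromatic carbon of the shared core, and none of them moves the read-out beyond the scatter.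

The step to compound 4 `CC(C)(C)Cc1c(-c2ccccc2)sc(N)c1C(=O)c1ccc(Cl)cc1Cl` is of a different kind: chloro in place of hydrogen on an aromatic carbon. Going by the values given here, none of the measured steps touches this part of the structure, so no measured step bears directly on it, and the only guide is that every change tried so far on the shared core has left the read-out where it was. The account therefore expects the step from compound 3 to compound 4 to be a number 2 percentage points higher from compound 3 to compound 4 (within the scatter), that is, nothing beyond the scatter in this assay. Compound 4 is expected to give about 3%, within a range from -7% to 13%.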

Compound 4, a percentage reported as inhibition, at one concentration (the size of the read-out at that concentration, not a potency): 1%
For compound 4 the middle estimate is 2 percentage points above the measured one; measured number inside the range.
By their numbers in this assay, from the lowest: compounds 1, 2, 3 and 4 (each within the scatter of the next).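

In this assay, turning 4-chlorophenyl into 2,4-dichlorophenyl gives no change at the digits printed from compound 3 to compound 4 (within the scatter). Going by these compounds alone, this is the first evidence on this place, an aromatic carbon ortho to a large group and meta to a chloro group, which none of the earlier steps reached: a chloro group here leaves the read-out within the scatter, just as phenyl and 3,4-dichlorophenyl did at the other aromatic carbon. No measurement at hand offers an explanation for this result.

As far as these compounds go, whether a group other than chloro at this place, such as a methoxy group, an amine or a carboxylic acid, would move the read-out beyond the scatter remains open. Also open is whether a longer chain in place of the branched alkyl group on the shared core would change this assay, since the steps shown leave that part of the structure untouched.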